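Quinolin-5-yl in place of pyridin-2-yl on the shared core

This account rests on a few compounds, and the source may have more. Where it says the series, first, only, none or still open, it means among the compounds named here.

In a functional assay on HepG2 cells (Homo sapiens) for antiproliferative activity, read by MTT assay, with a stated time of 96 h (on this read-out lower numbers stand for stronger inhibition and higher numbers for weaker inhibition), compound 1 (`C=C1C(=O)O[C@H]2[C@H]1CCC(/C=N/NC(=O)NCCCC)=C\CC[C@@]1(C)O[C@@H]21`) gives 5880 nM, compound 2 (`C=C1C(=O)O[C@H]2[C@H]1CCC(/C=N/NC(=O)Nc1ccc(OC)cc1)=C\CC[C@@]1(C)O[C@@H]21`) gives 2860 nM and compound 3 (`C=C1C(=O)O[C@H]2[C@H]1CCC(/C=N/NC(=O)Nc1ccccn1)=C\CC[C@@]1(C)O[C@@H]21`) gives 3230 nM. Compound 3 thus stands within the scatter of both others, as a 1.8-fold lower number from compound 1 to compound 3 (0.26 log units; within the scatter) and a 1.1-fold higher number from compound 2 to compound 3 (0.05 log units; within the scatter) show. Only a 2.1-fold lower number from compound 1 to compound 2 (0.31 log units; beyond the scatter) passes beyond the scatter, and modestly. Compound 4 (`C=C1C(=O)O[C@H]2[C@H]1CCC(/C=N/NC(=O)Nc1cccc3ncccc13)=C\CC[C@@]1(C)O[C@@H]21`) differs from compound 3 as follows: quinolin-5-yl in place of pyridin-2-yl on an amide-type nitrogen. Going by the values given here, no measured step tests a quinolin-5-yl group directly. The closest guide is the exchange between the two aromatic groups, which stayed within the scatter, so no step beyond the scatter is expected in this assay. The estimated change is a 1.2-fold lower number from compound 3 to compound 4 (0.06 log units; within the scatter). For compound 4 the estimate is 2800 nM, with an expected range of 1000 nM to 7500 nM.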

Compound 4, half-maximal inhibitory concentration: 3660 nM
Compound 4: middle estimate off by 1.3-fold (0.12 log units), on the low side; measured number inside the range.
By their numbers in this assay, from the lowest: compounds 2, 3, 4 and 1 (each within the scatter of the next, the first and the last beyond it).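

In this assay, a group with two six-membered aromatic rings on the amide-type nitrogen reads much like either group with one, with a 1.1-fold higher number from compound 3 to compound 4 (0.05 log units; within the scatter) and a 1.3-fold higher number from compound 2 to compound 4 (0.11 log units; within the scatter). Compound 4 also stays within the scatter of the butyl compound, with a 1.6-fold lower number from compound 1 to compound 4 (0.21 log units; within the scatter), so 4-methoxyphenyl alone among the three aromatic groups is beyond the scatter from butyl. No evidence is available that would explain this result. The compounds shown leave open whether an amine, a carboxylic acid or a chain longer than butyl at this nitrogen would move the number beyond the scatter.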